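From 3-bromophenyl to 4-acetylphenyl on the sulfonyl sulfur

The source may report more compounds than this note shows. Statements on the series, on what has been measured and on what is new or still open speak of the compounds shown alone.

- Compound 1 `Cc1ccc(S(=O)(=O)NC(C)C2=CC(=O)c3c(O)ccc(O)c3C2=O)cc1`: 30 nM
- Compound 2 `COc1ccc(S(=O)(=O)NC(C)C2=CC(=O)c3c(O)ccc(O)c3C2=O)cc1`: 20 nM
- Compound 3 `CC(NS(=O)(=O)c1cccc(Br)c1)C1=CC(=O)c2c(O)ccc(O)c2C1=O`: 160 nM

In a functional assay on HL-60 cells (Homo sapiens) for cytotoxicity, read by MTT assay (a higher number here means a weaker inhibitor, a lower number a stronger inhibitor), compound 3 gives the highest number of the three, 160 nM, which makes it the weakest inhibitor so far. Compound 4 `CC(=O)c1ccc(S(=O)(=O)NC(C)C2=CC(=O)c3c(O)ccc(O)c3C2=O)cc1` has 4-acetylphenyl in place of 3-bromophenyl on a sulfonyl sulfur.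

Within the data shown here, two measured steps bear on this change, both ending at the 3-bromophenyl group: a 5.3-fold higher number from compound 1 to compound 3 (0.73 log units; beyond the scatter) and an 8.0-fold higher number from compound 2 to compound 3 (0.90 log units; beyond the scatter). Changing methyl to methoxy made little difference: a 1.5-fold lower number from compound 1 to compound 2 (0.18 log units; within the scatter). Among the measured compounds shown here, no acetyl compound has been measured, so only part of that gap should close.

The expected change is a 3.2-fold lower number from compound 3 to compound 4 (0.51 log units; beyond the scatter). For compound 4, the estimate is 50 nM, with an expected range of 15 nM to 170 nM.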

Compound 4, half-maximal inhibitory concentration: 260 nM
Compound 4: the middle estimate sits 5.2-fold (0.72 log units) below what was measured; measured number above the stated range.
By their numbers in this assay, from the lowest: compounds 2 and 1 (each within the scatter of the next); then compounds 3 and 4 (each within the scatter of the next).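

In this assay the change to 4-acetylphenyl on the sulfonyl sulfur gives a 1.6-fold higher number from compound 3 to compound 4 (0.21 log units; within the scatter) and so does not bring compound 4 clear of compound 3. Acetyl on the aromatic carbon separates it from the methyl and methoxy compounds, with an 8.7-fold higher number from compound 1 to compound 4 (0.94 log units; beyond the scatter) and a 13-fold higher number from compound 2 to compound 4 (1.11 log units; beyond the scatter) as the steps. Among the groups shown, only methyl and methoxy give low numbers here, while acetyl and 3-bromophenyl do not.

As far as these compounds go, whether an amine or a carboxylic acid on that aromatic carbon would match methoxy or acetyl stays open. Nothing available explains why acetyl and methoxy differ so widely.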